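An Ethyl Group Added to Compound 1

A few compounds are considered here, and "the series" means these few. Any claim that something is new, unique, unknown or untested is made for them only; others in the source may bear on it.

Compound 1 `S=C(N/N=C/c1cccs1)Nc1ccccc1`: 94600 nM
Compound 2 `S=C(N/N=C/c1cccs1)Nc1cccc2ccccc12`: > 100000 nM

Going by the values given here, in a functional assay on MCF7 cells (Homo sapiens) for inhibition, read by sulforhodamine B assay, with a stated time of 48 h (on this read-out lower numbers stand for stronger inhibition of growth and higher numbers for weaker inhibition of growth), compound 1 gives 94600 nM, the only number in the set. Compound 2 sits at the limit of > 100000 nM in this assay, at which 1 of the 2 values shown sits, which is a limit and not a number. Compound 3 `CCc1ccc(NC(=S)N/N=C/c2cccs2)cc1` differs from compound 1 by ethyl in place of hydrogen on an aromatic carbon. Among the compounds with values here, with no measured step of this kind to lean on, the change from compound 1 to compound 3 is expected to be small, at most a slight strengthening, and likely within the scatter. The step from compound 1 to compound 3 is estimated as a 1.5-fold lower number from compound 1 to compound 3 (0.16 log units; within the scatter), giving compound 3 an expected 65000 nM, between 25000 nM and 150000 nM.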

Compound 3, concentration for 50% growth inhibition: > 100000 nM
Compound 3 ended at the assay's limit; the forecaster's own chance of this, stated with the estimate: 25%; middle value at least 1.5-fold (0.18 log units) from the limit.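

In this assay, going by these compounds alone, the change at this position, para to a large group, gives an at least 1.0-fold higher number from compound 1 to compound 3 (0.02 log units; that floor lies within the scatter), and this is the first measured step at this place on the shared core. Ethyl in place of hydrogen here brought no strengthening that the read-out can show, and the step has only a floor, not a size. Compound 3 gives a limit and not a number: the limit of > 100000 nM in this assay, at which 2 of the 3 values shown sit.

On these data alone, how far the true value of compound 3 lies past that limit stays open. Also open, as far as these compounds go, is whether methyl, an amine or a carboxylic acid on the same aromatic carbon would give a lower number than compound 1 gives.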